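A few compounds are considered here, and "the series" means these few. Any claim that something is new, unique, unknown or untested is made for them only; others in the source may bear on it.

Measured in a functional assay on HT-29 cells (Homo sapiens) for inhibition, read by sulforhodamine B assay, with a stated time of 48 h, tested at 10 uM; a lower number here means less inhibition of growth, a higher number more inhibition of growth at the concentration tested:
- compound 1 `COc1ccc(-c2nc3sc(-c4ccccc4)cn3n2)cc1`: 70%
- compound 2 `C/C(=N/O)c1ccc(NC(=O)Cn2nc(C(F)(F)F)nc2N)cc1`: 11.9%

Compound 1 holds the higher of the two numbers in this assay. Its gap to compound 2 lies beyond the usual scatter, but the two structures do not differ in a single place, so that gap offers no guide to a single change.

Compound 3 `COc1ccc(-c2nc3sc(-c4ccc(Cl)cc4)cn3n2)cc1` is still to be measured. It differs from compound 1 by chloro in place of hydrogen on an aromatic carbon, para to a large group, so that phenyl becomes 4-chlorophenyl. Within the data shown here, no measured pair shows this change, so the expectation rests only on compound 1 at 70%. The expected result is no change at the digits printed from compound 1 to compound 3 (within the scatter), with no step beyond the scatter and no firm direction. For compound 3 the estimated value is 70%, with an expected range of 50% to 88%.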

Compound 3, percent growth inhibition at one concentration: 82.7%
For compound 3 the middle estimate is 12.7 percentage points below the measured one; the range from low to high includes it.
By their numbers in this assay, from the lowest: compound 2; then compound 1; then compound 3.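

Chloro in place of hydrogen on an aromatic carbon, para to a large group, gives in this assay a step of a number 12.7 percentage points higher from compound 1 to compound 3 (beyond the scatter) and so turns phenyl into 4-chlorophenyl with a modest gain in growth inhibition. Among these compounds, this is the first difference that can be tied to one place, and it shows that this position accepts a chlorine atom with no loss of inhibition at the concentration tested. No measurement at hand bears on why the number moves.

The compounds shown leave open whether the step belongs to chloro alone or would also appear with fluoro, methyl or an amine in the same place. They also leave open whether a carboxylic acid at this position would keep the inhibition seen for compound 3.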